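Amide for thiazole at the styryl terminus of compound 1

The source may report more compounds than this note shows. Statements on the series, on what has been measured and on what is new or still open speak of the compounds shown alone.

Compound 1 `COC(=O)/C=C/c1cccc(N(Cc2ccc(/C=C/c3scnc3C)cc2)C(=O)C2CCCCC2)c1` is one of two with a number in an assay on isolated protein with Bile acid receptor (Homo sapiens) as the target (a lower number here means that less compound is needed, a higher number that more compound is needed for the effect), where compound 1 gives 227 nM. Compound 2 `CCOC/C=C/c1cccc(N(Cc2ccc(/C=C/C(=O)OC(C)(C)C)cc2)C(=O)C2CCCCC2)c1` gives 220 nM in this assay, a gap within the scatter, so no order between compound 1 and compound 2 can be read. Compound 3 `COC(=O)/C=C/c1cccc(N(Cc2cccc(OC)c2)C(=O)C2CCCCC2)c1` shows only the limit > 1000 nM in this assay; it is a limit and not a number (the limit of > 1000 nM in this assay, at which 1 of the 3 values shown sits). Compound 4 `COC(=O)/C=C/c1cccc(N(Cc2ccc(/C=C/C(=O)NC(C)(C)C)cc2)C(=O)C2CCCCC2)c1` is not yet measured; it differs from compound 1 by (tert-butyl)carbamoyl in place of 4-methyl-1,3-thiazol-5-yl on a double-bonded chain carbon bound to a double-bonded chain carbon. Compound 2, which also carries a tert-butyl-bearing acrylic group, gives 220 nM, so the step from compound 1 to compound 4 is expected to stay within the scatter, a 1.1-fold higher number from compound 1 to compound 4 (0.04 log units; within the scatter). Compound 4 is expected to give 250 nM, between 100 nM and 700 nM.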

Compound 4, half-maximal effective concentration: > 1000 nM
Compound 4 was reported as a limit; the forecaster's own chance of this, stated with the estimate: 10%; middle value at least 4.0-fold (0.60 log units) from the limit.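

In this assay, the group on a double-bonded chain carbon bound to a double-bonded chain carbon is not interchangeable: (tert-butyl)carbamoyl in place of 4-methyl-1,3-thiazol-5-yl gives an at least 4.4-fold higher number from compound 1 to compound 4 (0.64 log units; beyond the scatter). This is the only single-place step shown, and it isolates this position. The reading for compound 4 is a limit and not a number, so the step has only a lower bound: the limit of > 1000 nM in this assay, at which 2 of the 4 values shown sit.

As far as these compounds go, whether the aromatic ring, the amide or the tert-butyl group decides the outcome stays open. A phenyl ring or a carboxylic acid at this place would help separate these readings.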